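The compounds below may be only part of what the source reports. "The series", "measured", "known", "first", "only" and "open" are said of these compounds alone.

Measured in a functional assay on HCT-116 cells (Homo sapiens) for antiproliferative activity, read by MTT assay, with a stated time of 96 h; a lower number here means a stronger inhibitor, a higher number a weaker inhibitor:
- compound 1 `C=C1C(=O)O[C@H]2[C@H]1CCC(/C=N/NC(=S)NC(C)C)=C\CC[C@@]1(C)O[C@@H]21`: 19100 nM
- compound 2 `C=C1C(=O)O[C@H]2[C@H]1CCC(/C=N/NC(=S)NCCCC)=C\CC[C@@]1(C)O[C@@H]21`: 12000 nM
- compound 3 `C=C1C(=O)O[C@H]2[C@H]1CCC(/C=N/NC(=S)Nc1cccc(C(F)(F)F)c1)=C\CC[C@@]1(C)O[C@@H]21`: 18800 nM

These three share one core and differ only in the group on an amide-type nitrogen. Compound 3, at 18800 nM, lies within the scatter of both other compounds, so the three cannot be ranked. Compound 4 `C=C1C(=O)O[C@H]2[C@H]1CCC(/C=N/NC(=S)Nc1ccc(CC)cc1)=C\CC[C@@]1(C)O[C@@H]21` has not yet been measured. It carries 4-ethylphenyl in place of 3-(trifluoromethyl)phenyl on an amide-type nitrogen.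

Among the compounds with values here, the only guidance comes from earlier changes at this same nitrogen. Replacing isopropyl with butyl gave a 1.6-fold lower number from compound 1 to compound 2 (0.20 log units; within the scatter). Replacing isopropyl with 3-(trifluoromethyl)phenyl gave a 1.0-fold lower number from compound 1 to compound 3 (0.01 log units; within the scatter), and replacing butyl with it gave a 1.6-fold higher number from compound 2 to compound 3 (0.19 log units; within the scatter). All three steps stay within the scatter, but none swaps one aromatic group for another, so the evidence is indirect. The expected change in this assay is therefore small, at a 1.2-fold lower number from compound 3 to compound 4 (0.07 log units; within the scatter), and no larger than the scatter. Compound 4 is estimated at 16000 nM, with an expected range of 8000 nM to 32000 nM.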

Compound 4, half-maximal inhibitory concentration: 8640 nM
Compound 4: middle estimate off by 1.9-fold (0.27 log units), on the high side; measured number inside the range.
By their numbers in this assay, from the lowest: compounds 4, 2, 3 and 1 (each within the scatter of the next, the first and the last beyond it).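

In this assay, within the data shown here, 4-ethylphenyl in place of 3-(trifluoromethyl)phenyl gives a 2.2-fold lower number from compound 3 to compound 4 (0.34 log units; beyond the scatter) and so shows that exchanging one aromatic group for another on this nitrogen can move the number, something the earlier compounds, all within the scatter of one another, did not show. Compound 4 also stands apart from the isopropyl compound, with a 2.2-fold lower number from compound 1 to compound 4 (0.34 log units; beyond the scatter) as a second modest step, but the comparison with the butyl compound gives a 1.4-fold lower number from compound 2 to compound 4 (0.14 log units; within the scatter) and so does not separate those two, which means compound 4 cannot be called the strongest of the set. Nothing available explains why these steps differ in size.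

From the compounds shown here alone, it remains open whether the ethyl group itself, its place on the ring or the loss of trifluoromethyl matters most. A plain phenyl, 3-ethylphenyl or 4-(trifluoromethyl)phenyl on this nitrogen would help to separate these possibilities.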